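The source may hold more compounds than are shown below. What is called first, only, known or untested is meant among the compounds shown, and "the series" means these compounds.

Compound 1 `CC[C@@H](NC(=O)c1ccc(Cl)s1)C(=O)Nc1ccc(N2CCOCC2=O)c(C)c1` and compound 2 `Cc1cc(NC(=O)[C@@H](C)NC(=O)c2ccc(Cl)s2)ccc1N1CCOCC1=O` share one core and differ only at a saturated chain carbon, two bonds along the chain from an amide-type nitrogen and a carbonyl carbon. In an assay on isolated protein for inhibition of Trypsin (Homo sapiens) (a higher number here means a weaker inhibitor, a lower number a stronger inhibitor), compound 1 gives only a limit, > 10000 nM. In this assay compound 2 likewise gives only a limit, > 10000 nM. The step from compound 1 to compound 2 a step that the two limits leave unreadable from compound 1 to compound 2 cannot be sized because of the limit of > 10000 nM in this assay, at which 2 of the 2 values shown sit. So compound 2 stands among the values that are limits rather than numbers, with no figure of its own.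

Compound 3 `CCCOC[C@@H](NC(=O)c1ccc(Cl)s1)C(=O)Nc1ccc(N2CCOCC2=O)c(C)c1` is reached from compound 2 by one change: propoxy in place of hydrogen on a saturated chain carbon, two bonds along the chain from an amide-type nitrogen and a carbonyl carbon. For the measured compounds named here, the only measured step at this carbon is the one from compound 1 to compound 2, and it is unreadable, so it gives no direction for the present change. With both known compounds at the limit, compound 3 is expected to remain weak in this assay, the estimated step being a step that the limit leaves unreadable from compound 2 to compound 3. Compound 3 is estimated at 15000 nM, within a range from 4000 nM to 60000 nM.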

Compound 3, half-maximal inhibitory concentration: > 10000 nM
Compound 3 gave a limit, no number; the forecaster's own chance of this, stated with the estimate: 80%; the middle value does not contradict the limit.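

Compound 3 also gives only a limit in this assay, so no step among compound 1, compound 2 and compound 3 can be read: the limit of > 10000 nM in this assay, at which 3 of the 3 values shown sit.

The compounds shown leave open whether any change at this saturated chain carbon alters inhibition, since none of them has a numerical value.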